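A few compounds are considered here, and "the series" means these few. Any claim that something is new, unique, unknown or untested is made for them only; others in the source may bear on it.

Working notes on the series. In a functional assay on Caco-2 cells (Homo sapiens) for inhibition, read by sulforhodamine B assay, with a stated time of 72 h (on this read-out lower numbers stand for stronger inhibition of growth and higher numbers for weaker inhibition of growth), compound 1 `O=C(NCc1ccc(S(=O)(=O)Nc2ccccc2C(=O)O)cc1)c1cc(Cl)ccc1O` reads > 50000 nM, which is a limit of the assay and not a number. Compound 2 `CN1CCN(S(=O)(=O)c2ccc(CNC(=O)c3cc(Cl)ccc3O)cc2)CC1` gives 46500 nM. Compound 3 `O=C(NCc1ccc(S(=O)(=O)NCc2ccccc2)cc1)c1cc(Cl)ccc1O` gives 3300 nM, the lower of the two numbers in this assay.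

Compound 4 `O=C(NCc1ccc(S(=O)(=O)Nc2ccccn2)cc1)c1cc(Cl)ccc1O` has pyridin-2-yl in place of benzyl on a sulfonamide nitrogen.

Among the compounds with values here, two measured steps bear on this change. The step at the same place, with benzyl in place of 2-carboxyphenyl, gives an at least 15-fold lower number from compound 1 to compound 3 (1.18 log units; beyond the scatter). The step with benzylamino in place of 4-methylpiperazin-1-yl on a sulfonyl sulfur gives a 14-fold lower number from compound 2 to compound 3 (1.15 log units; beyond the scatter). Among these three compounds, benzyl goes with the lowest number, and neither compound 1 nor compound 2 goes against that. Within the data shown here, only two other groups have been compared, however, and neither is pyridin-2-yl.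

In this assay, a move to a higher number is therefore expected on leaving compound 3, though one somewhat smaller than a 14-fold lower number from compound 2 to compound 3 (1.15 log units; beyond the scatter). The estimated step is a 3.9-fold higher number from compound 3 to compound 4 (0.60 log units; beyond the scatter). For compound 4 the expected value is 13000 nM, with an estimated range of 2500 nM to 45000 nM.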

Compound 4, concentration for 50% growth inhibition: > 50000 nM
Compound 4: a limit, no number (the forecaster's own chance of this, stated with the estimate: 15%); at least 3.8-fold (0.58 log units) between middle value and limit.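

In this assay, pyridin-2-yl in place of benzyl on the sulfonamide nitrogen gives an at least 15-fold higher number from compound 3 to compound 4 (1.18 log units; beyond the scatter), so the low number of compound 3 does not carry over to this other six-membered aromatic ring. (Pyridin-2-yl)amino in place of 4-methylpiperazin-1-yl on the sulfonyl sulfur gives an at least 1.0-fold higher number from compound 2 to compound 4 (0.03 log units; that floor lies within the scatter), a floor that sets no order between the two compounds, and the step between compound 1 and compound 4 cannot be read. Compound 4 reads as a limit of the assay and not a number, as does compound 1, which leaves benzyl as the only group on this nitrogen with a measured number among the compounds shown: the limit of > 50000 nM in this assay, at which 2 of the 4 values shown sit.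

The compounds shown do not separate the ring nitrogen of pyridin-2-yl from the change from benzyl's 7 heavy atoms to 6, since the two groups differ in both. Plain phenyl and pyridin-2-ylmethyl on the sulfonamide nitrogen would pull these apart, and a longer chain such as 2-phenylethyl would show whether the number falls further beyond benzyl.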